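The source may hold more compounds than are shown below. What is called first, only, known or untested is meant among the compounds shown, and "the series" means these compounds.

Series notes. The three measured compounds share one core and differ only in what sits on the sulfonamide nitrogen: compound 1 `O=S(=O)(Nc1ccc(O)cc1)c1ccc2nc(-c3ccccc3)c(-c3ccccc3)nc2c1`, compound 2 `O=S(=O)(Nc1ccc2ccccc2c1)c1ccc2nc(-c3ccccc3)c(-c3ccccc3)nc2c1` and compound 3 `O=S(=O)(Nc1ccccc1)c1ccc2nc(-c3ccccc3)c(-c3ccccc3)nc2c1`. In an ADME assay on the whole organism for pharmacokinetics, with Homo sapiens as the target (on this read-out higher numbers stand for higher oral bioavailability and lower numbers for lower oral bioavailability), compound 1 gives 93.9%, compound 2 gives 100% and compound 3 gives 100%. Compound 2 stands level with compound 3 at the digits shown, the two together the highest of the three numbers, with compound 1 the furthest away; all three lie within the scatter of one another, as the steps of a number 6.1 percentage points higher from compound 1 to compound 2 (within the scatter), a number 6.1 percentage points higher from compound 1 to compound 3 (within the scatter) and no change at the digits printed from compound 2 to compound 3 (within the scatter) show.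

The next step goes from compound 2 to compound 4 `O=C(NS(=O)(=O)c1ccc2nc(-c3ccccc3)c(-c3ccccc3)nc2c1)c1ccccc1`, the change being (benzoyl in place of naphthalen-2-yl on a sulfonamide nitrogen). Among the compounds with values here, none of the measured steps exchanges an aryl group on the sulfonamide nitrogen for benzoyl; the nearest comparisons, naphthalen-2-yl for 4-hydroxyphenyl, phenyl for naphthalen-2-yl and hydrogen for hydroxy, all stayed within the scatter. On that basis no step beyond the scatter is expected in this assay, with some allowance for a lower number, so compound 4 is estimated at 88%, between 65% and 100%, an expected step of a number 12 percentage points lower from compound 2 to compound 4 (beyond the scatter).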

Compound 4, oral bioavailability: 100%
Compound 4: middle estimate off by 12 percentage points, on the low side; the measured number falls inside the stated range.
By their numbers in this assay, from the lowest: compounds 1, 2, 3 and 4 (each within the scatter of the next).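

Benzoyl on the sulfonamide nitrogen, the first group here joined through a carbonyl rather than directly through an aromatic ring, leaves this assay within the scatter of all three aryl compounds, with no change at the digits printed from compound 2 to compound 4 (within the scatter) and no change at the digits printed from compound 3 to compound 4 (within the scatter) and also a number 6.1 percentage points higher from compound 1 to compound 4 (within the scatter) as the steps. The position therefore accepts this change of linkage, along with the hydrogen-bond acceptor counted for benzoyl, and the series still shows no step beyond the scatter at this nitrogen. Nothing at hand bears on why the number holds across this change.

The compounds shown leave open whether any group on this nitrogen moves the read-out beyond the scatter. Going by these compounds, a short alkyl chain, an acetyl group or a benzoyl carrying an amine or a carboxylic acid could each test that, and the shared core stays unexplored as well.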